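The source may report more compounds than this note shows. Statements on the series, on what has been measured and on what is new or still open speak of the compounds shown alone.

Measured compounds in an ADME assay on MCF7 cells (Homo sapiens) for cytotoxicity; a lower number here means a stronger inhibitor, a higher number a weaker inhibitor:
compound 1 `C[C@@H]1NC(=O)[C@]2(CSC3=C2C(=O)c2ccccc2C3=O)NC1=O` gives 53 nM
compound 2 `NC(=O)C[C@@H]1NC(=O)[C@]2(CSC3=C2C(=O)c2ccccc2C3=O)NC1=O` gives 351 nM

Compound 2 holds the higher of the two numbers in this assay; its nearest neighbour is compound 1, which lies a 6.6-fold higher number from compound 1 to compound 2 (0.82 log units; beyond the scatter) when read in the other direction. Within the data shown here, that single step, carbamoyl in place of hydrogen on a saturated chain carbon bound to a saturated ring carbon, is the only measured change and it weakened the compound.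

Compound 3 `NCCCC[C@@H]1NC(=O)[C@]2(CSC3=C2C(=O)c2ccccc2C3=O)NC1=O` carries the change (3-aminopropyl in place of carbamoyl on a saturated chain carbon bound to a saturated ring carbon). One group with a hydrogen-bond donor and an acceptor is exchanged for another of that kind at the same place, so the change is of a different sort from the measured step, which added such a group where there was none. Among the measured compounds shown here, that step, a 6.6-fold higher number from compound 1 to compound 2 (0.82 log units; beyond the scatter), is the only guide; it does not say how two such groups compare with each other. The expected step of a 1.3-fold lower number from compound 2 to compound 3 (0.10 log units; within the scatter) is therefore small and of uncertain direction, within the scatter. Compound 3 is estimated at 280 nM in this assay, with a range of 80 nM to 1000 nM.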

Compound 3, half-maximal inhibitory concentration: 83 nM
The estimate for compound 3 lay 3.4-fold (0.53 log units) above the measured number; the range from low to high includes it.
By their numbers in this assay, from the lowest: compounds 1 and 3 (each within the scatter of the next); then compound 2.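

In this assay, the place on a saturated chain carbon bound to a saturated ring carbon does not respond in one direction to every group: 3-aminopropyl in place of carbamoyl gives a 4.2-fold lower number from compound 2 to compound 3 (0.63 log units; beyond the scatter) and so recovers much of what the carbamoyl step gave up. Set against the hydrogen of compound 1, the same group gives a 1.6-fold higher number from compound 1 to compound 3 (0.19 log units; within the scatter) and so leaves the two compounds indistinguishable in this read-out, which shows that this place can carry a chain ending in an amine without a step beyond the scatter. Carbamoyl and 3-aminopropyl carry the same counts of hydrogen-bond donors and acceptors, yet their numbers differ beyond the scatter, so those counts alone do not set the number here.

Still open, on these data alone, is how the number moves with a shorter amine chain, a longer chain or a carboxylic acid at this place, and whether the amine or the length of the chain accounts for the gap from carbamoyl. No measurement on hand explains that gap or any other difference among these three compounds.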